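The compounds below may be only part of what the source reports. "The series", "measured", "known", "first", "only" and "open" are said of these compounds alone.

Compound 1 `Cc1ccc(NC(=S)NC(=O)c2ccc(OCc3ccccc3)cc2)cc1-c1nc2ccccc2[nH]1` carries a benzyloxy group on the benzoyl part of the shared core. In a functional assay on SW-620 cells (Homo sapiens) for inhibition, read by MTT assay, with a stated time of 48 h (a lower number here means a stronger inhibitor, a higher number a weaker inhibitor), compound 1 gives 67100 nM. Compound 2 `Cc1ccc(NC(=S)NC(=O)c2ccc(OCc3cccc(Cl)c3Cl)cc2)cc1-c1nc2ccccc2[nH]1` replaces the phenyl of that group with 2,3-dichlorophenyl. In this assay compound 2 gives only > 100000 nM, which is a limit of the measurement and not a number. Compound 3 `Cc1ccc(NC(=S)NC(=O)c2ccc(OCc3cccc(F)c3)cc2)cc1-c1nc2ccccc2[nH]1` instead bears a 3-fluorophenyl there. In this assay compound 3 likewise gives only > 100000 nM, again a limit rather than a number. Compound 3 thus stands at the limit of > 100000 nM in this assay, at which 2 of the 3 values shown sit, and no exact number is known for it. Across the measured compounds there is an at least 1.4-fold higher number from compound 1 to compound 2 (0.17 log units; that floor lies within the scatter) and also an at least 1.4-fold higher number from compound 1 to compound 3 (0.17 log units; that floor lies within the scatter), both pointing toward weaker inhibition, while between compound 2 and compound 3 there is a step that the two limits leave unreadable from compound 2 to compound 3. Compound 4 `Cc1ccc(NC(=S)NC(=O)c2ccc(OCc3ccc(F)cc3)cc2)cc1-c1nc2ccccc2[nH]1` differs from compound 3 by 4-fluorophenyl in place of 3-fluorophenyl on a saturated chain carbon bound to an oxygen on an aromatic ring. Going by the values given here, no measured step moves the fluorine within the ring, so the measured steps bear only indirectly on this change. Compound 4 is therefore expected to remain near the limit as well. The step of a number no higher from compound 3 to compound 4 (the limit leaves the size open) is expected to be small. The estimate for compound 4 is 100000 nM, ranging between 40000 nM and 250000 nM.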

Compound 4, half-maximal inhibitory concentration: 40500 nM
Beside the measured number, compound 4's estimate is 2.5-fold (0.39 log units) above it, and the stated range covers the measured number.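

Within this assay, the two fluorophenyl groups have the same atoms, so the step of an at least 2.4-fold lower number from compound 3 to compound 4 (0.39 log units; beyond the scatter) comes from where the fluorine sits on the ring, something no earlier step could show. The step of an at least 2.4-fold lower number from compound 2 to compound 4 (0.39 log units; beyond the scatter) is also beyond the usual scatter, so a substituted ring on this benzyloxy group does not always leave a compound at the limit of the assay. Even so, the step of a 1.7-fold lower number from compound 1 to compound 4 (0.22 log units; within the scatter) lies within the scatter, so the fluorine in the 4-fluorophenyl group of compound 4 gives no readable gain over the plain phenyl group of compound 1, and the two compounds count as level.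

Going by these compounds, the true size of the steps from compound 2 and compound 3 stays open, as each of those compounds has a limit and not a number: the limit of > 100000 nM in this assay, at which 2 of the 4 values shown sit. On these data alone, it is also open whether a chlorine atom or a methoxy group in place of the fluorine of compound 4 would keep the compound measurable in this assay or return it to that limit.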